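The compounds below may be only part of what the source reports. "The series", "measured", "known", "first", "only" and "open" are said of these compounds alone.

Measured compounds in a functional assay on A549 cells (Homo sapiens) for inhibition, read by MTT assay, with a stated time of 48 h; a higher number here means a weaker inhibitor, a lower number a stronger inhibitor:
compound 1 `O=C1N/C(=N\Cc2ccccc2)S/C1=C1/CCNC(=O)c2[nH]ccc21` — 26900 nM
compound 2 `COc1ccc(C/N=C2\NC(=O)/C(=C3\CCNC(=O)c4[nH]ccc43)S2)cc1` — 18300 nM
compound 3 `CC(C)(C)c1ccc(C/N=C2\NC(=O)/C(=C3\CCNC(=O)c4[nH]ccc43)S2)cc1` — 43900 nM

Compound 2 carries the lowest of the three numbers. The step of a 1.5-fold lower number from compound 1 to compound 2 (0.17 log units; within the scatter) lies within the scatter, so compound 1 and compound 2 cannot be ordered; only a 2.4-fold higher number from compound 2 to compound 3 (0.38 log units; beyond the scatter) stands beyond it, a modest gap.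

Compound 4 `O=C1N/C(=N\Cc2ccc(F)cc2)S/C1=C1/CCNC(=O)c2[nH]ccc21` differs from compound 2 by fluoro in place of methoxy on an aromatic carbon. Within the data shown here, the steps that bear on it are a 1.5-fold lower number from compound 1 to compound 2 (0.17 log units; within the scatter), where methoxy enters on the same aromatic carbon to no clear effect, and a 1.6-fold higher number from compound 1 to compound 3 (0.21 log units; within the scatter), also within the scatter. The substituent at this position has so far moved this assay only modestly at most, so the expected step of a 1.3-fold higher number from compound 2 to compound 4 (0.10 log units; within the scatter) is small, likely a slightly higher number, not beyond the scatter. Compound 4 is therefore expected to give about 23000 nM, within 11000 nM to 48000 nM.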

Compound 4, half-maximal inhibitory concentration: 22400 nM
Estimate against measurement, compound 4: 1.0-fold (0.01 log units) above; low and high end bracket the measured number.
By their numbers in this assay, from the lowest: compounds 2, 4, 1 and 3 (each within the scatter of the next, the first and the last beyond it).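

Fluoro is the first halogen at this aromatic carbon, and in this assay it separates from neither hydrogen (a 1.2-fold lower number from compound 1 to compound 4 (0.08 log units; within the scatter)) nor methoxy (a 1.2-fold higher number from compound 2 to compound 4 (0.09 log units; within the scatter)). Even against tert-butyl the step stays within the scatter (a 2.0-fold lower number from compound 3 to compound 4 (0.29 log units; within the scatter)), so the only gap beyond the scatter remains the one between compound 2 and compound 3. No available measurement offers an explanation for these numbers.

Going by these compounds, whether an amine or a carboxylic acid on this carbon would move the number clearly away from this narrow band stays open. On these data alone, the effect of any change to the shared core also stays open.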